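The source may hold more compounds than are shown below. What is called first, only, known or untested is meant among the compounds shown, and "the series" means these compounds.

In a functional assay on MKN-45 cells (Homo sapiens) for antiproliferative activity, with a stated time of 72 h (a higher number here means a weaker inhibitor, a lower number a stronger inhibitor), compound 1 `Cn1cc(-c2ccc(NC(=O)c3cn(CC4CCOCC4)cc(-c4ccc(F)cc4F)c3=O)cc2)c2c(N)ncnc21` gives 501 nM and compound 2 `Cn1cc(-c2ccc(NC(=O)c3cn(CC4CCOCC4)cc(-c4ccc(F)cc4)c3=O)c(F)c2)c2c(N)ncnc21` gives 210 nM while compound 3 `Cn1cc(-c2ccc(NC(=O)c3cn(CC4CCOCC4)cc(-c4ccc(Cl)cc4)c3=O)cc2)c2c(N)ncnc21` gives 347 nM and so stands within the scatter of both of the others. Compound 4 `Cn1cc(-c2ccc(NC(=O)c3cn(CC4CCOCC4)cc(-c4ccccc4)c3=O)cc2)c2c(N)ncnc21` is the unmeasured neighbour of compound 3: hydrogen in place of chloro on an aromatic carbon, para to a large group, which reads as 4-chlorophenyl to phenyl hydrogen in place of chloro on an aromatic carbon in the counted change. For the measured compounds named here, only one measured step touches this phenyl group, namely a 1.4-fold lower number from compound 1 to compound 3 (0.16 log units; within the scatter) and it swaps one substituted phenyl for another. Going by the values given here, no measured pair shows the chloro removed outright, and no single change links compound 2 to the others. On this thin evidence, no step beyond the scatter is expected in this assay. The estimated move is a 1.2-fold higher number from compound 3 to compound 4 (0.06 log units; within the scatter) and it is expected to stay small. For compound 4 the expected value is 400 nM with an estimated range from 170 nM to 950 nM.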

Compound 4, half-maximal inhibitory concentration: 318 nM
Compound 4: middle estimate off by 1.3-fold (0.10 log units), on the high side; the measured number falls inside the stated range.
By their numbers in this assay, from the lowest: compounds 2, 4, 3 and 1 (each within the scatter of the next, the first and the last beyond it).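

In this assay hydrogen in place of chloro on an aromatic carbon, para to a large group, gives a 1.1-fold lower number from compound 3 to compound 4 (0.04 log units; within the scatter) and so shows directly that taking the chloro off this ring does not move the number beyond the scatter. Phenyl in place of 2,4-difluorophenyl gives a 1.6-fold lower number from compound 1 to compound 4 (0.20 log units; within the scatter), which places the unsubstituted phenyl within the scatter of the difluorinated ring as well, so compound 1, compound 3 and compound 4 are not separated by this assay. No measurement offered here bears on why these steps stay small.

Going by these compounds, what an amine or a carboxylic acid on this phenyl ring would do to the number remains open. Compound 2 is joined to the others by no single change, so the contribution of each of its differences cannot be read.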